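Swapping the sulfonamide aryl group: trifluoromethylphenyl to acetamidophenyl

A few compounds are considered here, and "the series" means these few. Any claim that something is new, unique, unknown or untested is made for them only; others in the source may bear on it.

Measured compounds in an ADME assay on MT4 cells (Homo sapiens) for cytotoxicity, read by MTT assay, with a stated time of 5 days; on this read-out lower numbers stand for higher toxicity in this test and higher numbers for lower toxicity in this test:
- Compound 1, `Cc1cc(C#N)cc(C)c1Oc1nc(NC2CCC(NS(=O)(=O)c3cccc(C(F)(F)F)c3)CC2)nc2ccsc12`, gives 6680 nM.
- Compound 2, `Cc1cc(C#N)cc(C)c1Oc1nc(NC2CCC(NC(=O)c3ccc(C#N)cc3)CC2)nc2ccsc12`, gives 2620 nM.
- Compound 3, `Cc1cc(C#N)cc(C)c1Oc1nc(NC2CCC(NC(=O)c3cccc(C(F)(F)F)c3)CC2)nc2ccsc12`, gives 3240 nM.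

Compound 1 holds the highest number of the three in this assay; compound 3 lies nearest to it and compound 2 furthest, and both gaps are beyond the scatter. Compound 4, `CC(=O)Nc1ccc(S(=O)(=O)NC2CCC(Nc3nc(Oc4c(C)cc(C#N)cc4C)c4sccc4n3)CC2)cc1`, differs from compound 1 in one place: 4-acetamidophenyl in place of 3-(trifluoromethyl)phenyl on a sulfonyl sulfur. The only measured single step among these compounds is a 1.2-fold higher number from compound 2 to compound 3 (0.09 log units; within the scatter), which exchanges the same trifluoromethylphenyl group on a carbonyl rather than a sulfonyl, and it stayed within the scatter. That step bears only loosely on the present change, since the entering group there was a cyanophenyl, not an acetamidophenyl. On this basis compound 4 is expected to sit close to compound 1 in this assay, with a step of a 1.0-fold higher number from compound 1 to compound 4 (0.02 log units; within the scatter) that is estimated to be small and of no reliable direction. The estimate for compound 4 in this assay is 7000 nM, within 3000 nM to 16000 nM.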

Compound 4, half-maximal cytotoxic concentration: 3730 nM
Compound 4: the middle estimate sits 1.9-fold (0.27 log units) above what was measured; the range from low to high includes it.
By their numbers in this assay, from the lowest: compounds 2, 3, 4 and 1 (each within the scatter of the next, the first and the last beyond it).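

In this assay the exchange on the sulfonyl sulfur, 4-acetamidophenyl in place of 3-(trifluoromethyl)phenyl, gives a 1.8-fold lower number from compound 1 to compound 4 (0.25 log units; within the scatter). The result therefore gives a direct reading at the sulfonyl sulfur, where the earlier single step concerned a carbonyl carbon: a group with a hydrogen-bond donor and a hydrogen-bond acceptor replaces one with neither, and the two numbers cannot be told apart from repeat measurements. No measurement shown bears on why this step has the size it does.

Going by these compounds, whether a carboxylic acid or an amine on the phenyl ring, or a plain methyl in place of the aryl group on the sulfonyl sulfur, would give a step beyond the scatter remains open. On these data alone, it is also open whether 4-acetamidophenyl would give a similar result on the carbonyl carbon.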